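This account rests on a few compounds, and the source may have more. Where it says the series, first, only, none or still open, it means among the compounds named here.

Measured compounds:
compound 1 `COc1cc(/C=C/C(=O)C2=C(/C=C/c3ccc(O)c(OC)c3)NC(=O)NC2c2ccccc2)ccc1O` — 38.2%
compound 2 `COc1cc(/C=C/C(=O)C2=C(/C=C/c3ccc(O)c(OC)c3)NC(=O)NC2c2ccccc2O)ccc1O` — 81%

In a functional assay, with a stated time of 20 min, tested at 20 uM (on this read-out higher numbers stand for a stronger effect at the one concentration tested and lower numbers for a weaker effect), compound 2 stands highest of the two numbers; its nearest neighbour is compound 1, and the step of a number 42.8 percentage points higher from compound 1 to compound 2 (beyond the scatter) lies beyond the scatter. Compound 3 `COc1cc(/C=C/C(=O)C2=C(/C=C/c3ccc(O)c(OC)c3)NC(=O)NC2c2cccc([N+](=O)[O-])c2)ccc1O` is not yet measured. It differs from compound 2 in one place: 3-nitrophenyl in place of 2-hydroxyphenyl on a saturated ring carbon. Going by the values given here, the only measured step that bears on this change is a number 42.8 percentage points higher from compound 1 to compound 2 (beyond the scatter), which brought in the hydroxy that now leaves; the effect of the entering 3-nitrophenyl is not covered by any measured pair. A drop toward compound 1 is therefore expected, a number 36 percentage points lower from compound 2 to compound 3 (beyond the scatter), with wide uncertainty. For compound 3 the estimate in this assay is 45%, expected to fall between 25% and 70%.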

Compound 3, a percentage reported as activity, at one concentration (the size of the read-out at that concentration, not a potency): 66.3%
Beside the measured number, compound 3's estimate is 21.3 percentage points below it; the measured number falls inside the stated range.
By their numbers in this assay, from the lowest: compound 1; then compound 3; then compound 2.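

In this assay a gain on this phenyl does not depend on the hydroxy alone: nitro in place of hydrogen on an aromatic carbon gives a number 28.1 percentage points higher from compound 1 to compound 3 (beyond the scatter). Exchanging 2-hydroxyphenyl for 3-nitrophenyl on the saturated ring carbon gives a number 14.7 percentage points lower from compound 2 to compound 3 (beyond the scatter), so compound 2 stays ahead of compound 3 while compound 3 keeps much of the gain. No data on hand account for either step. Group and ring location change together between compound 2 and compound 3, so their contributions remain unseparated. On these data alone, whether an amine or a carboxylic acid on this phenyl would also raise the read-out remains open.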